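Swapping methoxy for methyl on the aryl ketone of compound 3

This account rests on a few compounds, and the source may have more. Where it says the series, first, only, none or still open, it means among the compounds named here.

Measured compounds:
- Compound 1, `COc1cc(-c2nnc3n2NC(c2cccs2)C(C(=O)c2ccc(C)cc2)S3)cc(OC)c1OC`: 12700 nM
- Compound 2, `COc1cc(-c2nnc3n2NC(c2cccs2)C(C(=O)c2ccc(F)cc2)S3)cc(OC)c1OC`: 45000 nM
- Compound 3, `COc1ccc(C(=O)C2Sc3nnc(-c4cc(OC)c(OC)c(OC)c4)n3NC2c2ccco2)cc1`: only a limit, > 100000 nM

These values come from a functional assay on A549 cells (Homo sapiens) for cytotoxicity, read by MTT assay, with a stated time of 48 h; on this read-out higher numbers stand for weaker inhibition and lower numbers for stronger inhibition. Compound 3 stands at the limit of this assay, a value that is not a number; (the limit of > 100000 nM in this assay, at which 1 of the 3 values shown sits). Within the data shown here, the only measured step, a 3.5-fold higher number from compound 1 to compound 2 (0.55 log units; beyond the scatter), concerns a different change and does not bear directly on methyl in place of methoxy. Compound 4, `COc1cc(-c2nnc3n2NC(c2ccco2)C(C(=O)c2ccc(C)cc2)S3)cc(OC)c1OC`, differs from compound 3 by methyl in place of methoxy on an aromatic carbon. Compound 1, which also carries methyl, gives 12700 nM, so compound 4 is expected to show a lower number than compound 3, an estimated at least 2.0-fold lower number from compound 3 to compound 4 (0.30 log units; that floor lies within the scatter). Compound 4 is expected to give about 50000 nM, between 12000 nM and 200000 nM.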

Compound 4, half-maximal inhibitory concentration: > 100000 nM
Compound 4 was reported as a limit; the forecaster's own chance of this, stated with the estimate: 40%; middle value at least 2.0-fold (0.30 log units) from the limit.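

Keeping the 4-methylphenyl group and putting furan-2-yl in place of thiophen-2-yl gives an at least 7.8-fold higher number from compound 1 to compound 4 (0.89 log units; beyond the scatter), so the ring on the saturated carbon matters here, which the earlier compounds did not show. The step from compound 3 to compound 4 cannot be read because both values are limits, not numbers: the limit of > 100000 nM in this assay, at which 2 of the 4 values shown sit.

As far as these compounds go, what methoxy would do alongside thiophen-2-yl stays open. So does whether an amine on the aryl ketone, or a pyridin-3-yl ring in place of furan-2-yl, would bring a measurable number.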